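The compounds below may be only part of what the source reports. "The series", "measured", "known", "first", "only" and "open" are said of these compounds alone.

Measured so far:
Compound 1, `COC(=O)c1ccc(NCc2cncn2Cc2cccc(C)c2)cc1-c1ccccc1`: in a toxicity assay on NIH3T3 cells (Mus musculus) for cytotoxicity, read by resazurin assay (a higher number here means that more compound is needed for the effect, a lower number that less compound is needed), compound 1 gives > 10000 nM, a limit of the assay and not a number.
Compound 2, `CCC(=O)c1ccc(NCc2cncn2Cc2ccc(-c3ccccc3)cc2)cc1-c1ccccc1`: compound 2 gives > 10000 nM, likewise a limit.

Compound 1 therefore stands at the limit of > 10000 nM in this assay, at which 2 of the 2 values shown sit; no numeric cytotoxicity is in hand for it. Compound 3, `COC(=O)c1ccc(NCc2cncn2Cc2ccc(C#N)cc2)cc1-c1ccccc1`, is not yet measured. It differs from compound 1 by 4-cyanophenyl in place of 3-methylphenyl on a saturated chain carbon bound to an aromatic nitrogen. The expected step that the limit leaves unreadable from compound 1 to compound 3 is none beyond the scatter, since both measured compounds sit at the limit. For compound 3 the estimate is 20000 nM, with a range from 8000 nM to 100000 nM, most likely reported again as a limit.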

Compound 3, half-maximal effective concentration: > 10000 nM
Compound 3 gave a limit, no number; the forecaster's own chance of this, stated with the estimate: 85%; the middle value is on the limit's open side.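

No step can be read from compound 1 to compound 3 in this assay, as both values are limits: the limit of > 10000 nM in this assay, at which 3 of the 3 values shown sit.

The compounds shown leave open what concentration gives cytotoxicity for any of them, and whether 4-cyanophenyl in place of 3-methylphenyl changes it.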